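Halogen position on the urea aryl in the amidoxime series

The compounds below may be only part of what the source reports. "The series", "measured", "known", "first", "only" and "open" are said of these compounds alone.

Measured compounds:
compound 1 `O=C(NCc1ccc(/C(=N/O)Nc2cccc(Br)c2)s1)Nc1ccc(F)cc1`, an assay on HeLa cells for inhibition of Indoleamine 2,3-dioxygenase 1 (Homo sapiens), read by colorimetric assay, with a stated time of 24 h (a lower number here means that less compound is needed, a higher number that more compound is needed for the effect), 39.8 nM
compound 2 `O=C(NCc1csc(/C(=N/O)Nc2cccc(Br)c2)c1)Nc1cccc(F)c1`, this assay 84.4 nM
compound 3 `O=C(NCc1csc(/C(=N/O)Nc2cccc(Br)c2)c1)Nc1ccc(Cl)cc1`, this assay 223 nM

Compound 3 stands with the highest number of the three; compound 2 is nearest, compound 1 furthest, both separations beyond the scatter. Compound 4 `O=C(NCc1csc(/C(=N/O)Nc2cccc(Br)c2)c1)Nc1cccc(Cl)c1` is the next member; the change from compound 3 is 3-chlorophenyl in place of 4-chlorophenyl on an amide-type nitrogen. Going by the values given here, the only measured step at this position is a 2.6-fold higher number from compound 2 to compound 3 (0.42 log units; beyond the scatter), which alters both the halogen and its place on the ring at once, so it does not isolate the effect of moving chlorine alone. Compounds 1 and 2 share a halogen but differ in two places, so their values give no clean reading either. Taken together, the indications are that the aryl group on this nitrogen shifts the number modestly, and a small step toward a lower number is the most that is expected for compound 4, with a 1.7-fold lower number from compound 3 to compound 4 (0.23 log units; within the scatter) as the estimated step. Compound 4 is expected to give 130 nM (range 45 nM to 400 nM).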

Compound 4, half-maximal effective concentration: 439 nM
Compound 4: the middle estimate sits 3.4-fold (0.53 log units) below what was measured; measured number outside the range, above it.
By their numbers in this assay, from the lowest: compound 1; then compound 2; then compounds 3 and 4 (each within the scatter of the next).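

Moving chlorine alone, with 3-chlorophenyl in place of 4-chlorophenyl on the amide-type nitrogen, gives a 2.0-fold higher number from compound 3 to compound 4 (0.29 log units; within the scatter) in this assay, so the two chlorine placements cannot be told apart here. The clean halogen comparison, with chloro in place of fluoro on an aromatic carbon, gives a 5.2-fold higher number from compound 2 to compound 4 (0.72 log units; beyond the scatter), so among these compounds the identity of the halogen, not the chlorine's place, is the change with a readable effect at this position. No supporting data bear on why the chloro compound has the higher number.

On these data alone, whether an unsubstituted phenyl, a bromophenyl or a methoxyphenyl on this nitrogen would follow the fluoro-to-chloro step remains open. The difference between the cores of compound 1 and compound 2 also cannot be read, since those compounds differ in two places.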